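The source may report more compounds than this note shows. Statements on the series, on what has been measured and on what is new or still open speak of the compounds shown alone.

Measured compounds:
compound 1, `Cc1cccc(C(=O)Nc2nn[nH]n2)n1`, 73%
compound 2, `Cc1ccnc(C(=O)Nc2nn[nH]n2)c1`, 51%

Two compounds share a core and differ only in where a methyl group sits. In a functional assay on the whole organism for inhibition, with Rattus norvegicus as the target, with a stated time of 5 min, at a dose of 3 mg/kg by the oral route (on this read-out lower numbers stand for less inhibition and higher numbers for more inhibition at the one dose given (going by the name of the read-out)), compound 1 gives 73%, while compound 2 gives 51%. Compound 2 thus stands lowest of the two numbers, and its nearest neighbour, compound 1, sits higher by a margin that lies beyond the scatter of this assay. For the measured compounds named here, no step between measured compounds that differ in a single place is available, so the pair shows only what its two values show: moving the methyl group between the two positions changes the read-out noticeably.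

Compound 3, `Cc1cc(C)nc(C(=O)Nc2nn[nH]n2)c1`, is not yet measured. It carries the methyl group of compound 2 and adds a second one; the change from compound 2 is methyl in place of hydrogen on an aromatic carbon. Compound 3 therefore holds the methyl placement of compound 1 as well.

Because compound 1 gives 73%, the step is expected to go upward, from compound 2 to compound 3 by about a number 17 percentage points higher from compound 2 to compound 3 (beyond the scatter), beyond the scatter. Compound 3 is estimated at 68%, within a range from 45% to 88%.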

Compound 3, a percentage reported as inhibition, in the whole organism at one dose (the size of the read-out at that dose, not a potency): 37%
The estimate for compound 3 lay 31 percentage points above the measured number, and the stated range ends above it.
By their numbers in this assay, from the lowest: compound 3; then compound 2; then compound 1.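

In this assay, methyl in place of hydrogen on the aromatic carbon next to the ring nitrogen gives a number 14 percentage points lower from compound 2 to compound 3 (beyond the scatter) on a core that already carries one methyl group, so at this position the change lowers the read-out in this setting. The other single change that leads to compound 3, again methyl in place of hydrogen on an aromatic carbon, gives a number 36 percentage points lower from compound 1 to compound 3 (beyond the scatter) and is the larger of the two steps, so compound 3 with its two methyl groups does not keep the higher number of compound 1. No measurement at hand accounts for either fall.

The compounds shown leave open whether the fall belongs to methyl itself or to any group placed on this carbon, a question that an ethyl group, a methoxy group, a chlorine atom or an amine there could address. They also leave open how the shared core behaves with hydrogen in place of both methyl groups, and so what either methyl group contributes on its own.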